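A few compounds are considered here, and "the series" means these few. Any claim that something is new, unique, unknown or untested is made for them only; others in the source may bear on it.

Working notes on a small set of acrylonitrile-type compounds tested in a functional assay on DU-145 cells (Homo sapiens) for inhibition, read by MTT assay, with a stated time of 72 h; a lower number here means a stronger inhibitor of growth, a higher number a weaker inhibitor of growth.

Compound 1 `N#C/C(=C\c1ccc(Cl)cc1)C(=O)c1ccc[nH]1` gives 61000 nM in this assay. Compound 3 `N#C/C(=C\c1ccco1)C(=O)NCc1ccc(Cl)c(Cl)c1` gives 24000 nM in this assay. Compound 2 `COc1ccc(CNC(=O)/C(C#N)=C/c2ccc[nH]2)cc1` reaches only the limit of this assay, > 50000 nM, and no number is known for it (the limit of > 50000 nM in this assay, at which 1 of the 3 values shown sits). Compound 2 therefore stands at the weak end of what the assay can report, and its place relative to the other two members is open.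

Compound 4 `COc1ccc(CNC(=O)/C(C#N)=C/c2cc(Br)co2)cc1` is not yet measured. It differs from compound 2 in a single place: 4-bromofuran-2-yl in place of 1H-pyrrol-2-yl on a double-bonded chain carbon bound to a double-bonded chain carbon. For the measured compounds named here, no measured pair in this set carries the same change, so the size of its effect is unknown here.

The expectation for the step from compound 2 to compound 4 is an at least 1.1-fold lower number from compound 2 to compound 4 (0.04 log units; that floor lies within the scatter), a change that is not expected to go beyond the scatter. Compound 4 is estimated at 45000 nM in this assay, within a range from 15000 nM to 130000 nM, with a real chance that only a limit is reported again.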

Compound 4, concentration for 50% growth inhibition: 61000 nM
Estimate against measurement, compound 4: 1.4-fold (0.13 log units) below; measured number inside the range.
By their numbers in this assay, from the lowest: compound 3; then compounds 1 and 4 (each within the scatter of the next).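

The step from compound 2 to compound 4 cannot be read in this assay, because compound 2 carries only a limit: the limit of > 50000 nM in this assay, at which 1 of the 4 values shown sits.

The compounds shown leave open whether 4-bromofuran-2-yl in place of 1H-pyrrol-2-yl changes growth inhibition at all, in either direction.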